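A few compounds are considered here, and "the series" means these few. Any claim that something is new, unique, unknown or untested is made for them only; others in the source may bear on it.

Notes on the series. Compound 1 `OCc1cn(Cc2cccc(F)c2)c2ccccc12` and compound 2 `OCc1cn(Cc2ccc(Cl)cc2)c2ccccc12` share one core and differ from each other in more than one place. In a functional assay on NCI-H460 cells (Homo sapiens) for cytotoxicity, read by sulforhodamine B assay, with a stated time of 3 days (on this read-out lower numbers stand for stronger inhibition and higher numbers for weaker inhibition), compound 1 gives 40 nM and compound 2 gives 16 nM. Within the data shown here, compound 1 thus stands highest of the two numbers measured, with compound 2 lower by a margin beyond the scatter; no single step links the pair.

Compound 3 `OCc1cn(Cc2cccc(I)c2)c2ccccc12` differs from compound 1 by iodo in place of fluoro on an aromatic carbon. Among the measured compounds shown here, no measured pair isolates this exchange, so the expected step from compound 1 to compound 3 is only a modest lowering, a 1.4-fold lower number from compound 1 to compound 3 (0.15 log units; within the scatter). In this assay compound 3 is estimated at 28 nM, within a range of 10 nM to 80 nM.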

Compound 3, half-maximal inhibitory concentration: 100 nM
Estimate against measurement, compound 3: 3.6-fold (0.55 log units) below; measured number outside the range, above it.
By their numbers in this assay, from the lowest: compound 2; then compound 1; then compound 3.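

Iodo in place of fluoro, on an aromatic carbon meta to a large group, gives a 2.5-fold higher number from compound 1 to compound 3 (0.40 log units; beyond the scatter) and so provides the first single-place step in the series. This place therefore responds to the exchange of one halogen for another, and here the change goes toward weaker inhibition. No measurement at hand accounts for this step.

From the compounds shown here alone, whether chloro or bromo on this same carbon would fall between the fluoro and iodo numbers remains open, as does the outcome with an amine or a methoxy group there. Compound 2 differs from compound 1 in more than one place, so the effect of moving a halogen around the ring also remains unresolved.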